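Swapping methoxy for methylsulfanyl on a P2Y2 agonist

The source may report more compounds than this note shows. Statements on the series, on what has been measured and on what is new or still open speak of the compounds shown alone.

Compound 2 `COc1ccc2ccn([C@@H]3O[C@H](COP(=O)(O)OP(=O)(O)OP(=O)(O)O)[C@@H](O)[C@H]3O)c(=O)c2c1` gives 26 nM in a functional assay for agonist activity at P2Y purinoceptor 2 (Homo sapiens), read by FLIPR (a higher number here means that more compound is needed for the effect, a lower number that less compound is needed), the lowest of the two numbers measured; compound 1 `Cc1ccc2ccn([C@@H]3O[C@H](COP(=O)(O)OP(=O)(O)OP(=O)(O)O)[C@@H](O)[C@H]3O)c(=O)c2c1` gives 148 nM. Compound 3 `CSc1ccc2ccn([C@@H]3O[C@H](COP(=O)(O)OP(=O)(O)OP(=O)(O)O)[C@@H](O)[C@H]3O)c(=O)c2c1` differs from compound 2 by methylsulfanyl in place of methoxy on an aromatic carbon. Among the measured compounds shown here, only one measured step touches that position: a 5.7-fold lower number from compound 1 to compound 2 (0.76 log units; beyond the scatter). For the measured compounds named here, no step compares methylsulfanyl with methoxy, so the direction is open. For compound 3 the expected step is a 1.9-fold higher number from compound 2 to compound 3 (0.28 log units; within the scatter), a modest loss that stays near the scatter. Compound 3 is therefore estimated at 50 nM, within a range of 15 nM to 200 nM.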

Compound 3, half-maximal effective concentration: 140 nM
Beside the measured number, compound 3's estimate is 2.8-fold (0.45 log units) below it, and the stated range covers the measured number.
By their numbers in this assay, from the lowest: compound 2; then compounds 3 and 1 (each within the scatter of the next).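

At this position, swapping the oxygen of methoxy for the sulfur of methylsulfanyl is not a neutral change, even though both groups have the same heavy-atom count and no net charge (a 5.4-fold higher number from compound 2 to compound 3 (0.73 log units; beyond the scatter)). Methylsulfanyl and methyl cannot be told apart in this assay (a 1.1-fold lower number from compound 1 to compound 3 (0.02 log units; within the scatter)), so among these three groups only methoxy stands apart. Nothing available explains why the oxygen and sulfur compounds differ. From the compounds shown here alone, whether an amine, a chlorine atom or a longer chain such as ethoxy would match methoxy remains open.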